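The source may report more compounds than this note shows. Statements on the series, on what has been measured and on what is new or still open speak of the compounds shown alone.

Compound 1 `COc1ccc2c(c1)OC/C(=C\c1ccccc1O)C2=O`: 1750 nM
Compound 2 `COc1cc(OC)c2c(c1)OC/C(=C\c1ccccc1O)C2=O`: 1260 nM
Compound 3 `COc1cc(O)c2c(c1)OC/C(=C\c1ccccc1O)C2=O`: not yet measured

In a functional assay on RAW264.7 cells (Mus musculus), read by Griess assay, with a stated time of 18 h (a lower number here means a stronger inhibitor, a higher number a weaker inhibitor), compound 2 gives 1260 nM, which lies within the scatter of compound 1. Compound 3 differs from compound 2 by hydrogen in place of methyl on an oxygen on an aromatic ring, so methoxy becomes hydroxy. For the measured compounds named here, only one measured step bears on this, and only indirectly: a 1.4-fold lower number from compound 1 to compound 2 (0.14 log units; within the scatter), for methoxy in place of hydrogen on an aromatic carbon. Going by the values given here, no measured compound carries this new hydroxy, so the expectation is loose, with no shift beyond the scatter in either direction. The expected change is a 1.1-fold higher number from compound 2 to compound 3 (0.05 log units; within the scatter). For compound 3 the estimate is 1400 nM, with an expected range of 500 nM to 4000 nM.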

Compound 3, half-maximal inhibitory concentration: 2090 nM
Beside the measured number, compound 3's estimate is 1.5-fold (0.17 log units) below it, and the stated range covers the measured number.
By their numbers in this assay, from the lowest: compounds 2, 1 and 3 (each within the scatter of the next).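

Within this assay the position now carries a free hydroxy, and that change can be read from two sides: hydroxy in place of methoxy (a 1.7-fold higher number from compound 2 to compound 3 (0.22 log units; within the scatter)) and hydroxy in place of hydrogen on the aromatic carbon (a 1.2-fold higher number from compound 1 to compound 3 (0.08 log units; within the scatter)). Both steps lie within the scatter, so hydrogen, methoxy and hydroxy on this position cannot be told apart in this assay. No supporting evidence is available to explain this result. Going by these compounds, whether an amine, a carboxylic acid or a longer chain here would give a step beyond the scatter remains open.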